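The compounds below may be only part of what the source reports. "The series", "measured", "known", "first", "only" and "open" are said of these compounds alone.

Of the compounds shown here, three built on one shared core have been measured in a functional assay on A549 cells (Homo sapiens) for cytotoxicity, read by MTT assay, with a stated time of 72 h; a higher number here means a weaker inhibitor, a lower number a stronger inhibitor. Compound 1 `CC1(C)O[C@@H](CO)[C@H](Cn2cc(Cn3c4c(c5ccccc53)C(=O)c3c[n+]([O-])c5ccccc5c3C4=O)nn2)O1` gives 370 nM, the highest of the three numbers. Compound 3 `CN(C)CCCCn1c2c(c3ccccc31)C(=O)c1c[n+]([O-])c3ccccc3c1C2=O` gives 310 nM, a value that lies within the scatter of the value of compound 1. Compound 2 `O=C1c2c[n+]([O-])c3ccccc3c2C(=O)c2c1c1ccccc1n2CCCCN1CCCCC1` gives 150 nM, which stands beyond the scatter below the value of compound 1. Among the compounds with values here, the one measured step between compounds that differ in a single place is a 2.1-fold higher number from compound 2 to compound 3 (0.32 log units; beyond the scatter); it concerns the amine on the chain and leaves the remainder of the molecule untouched. Compound 4 `CC1(C)OC[C@@H](Cn2cc(Cn3c4c(c5ccccc53)C(=O)c3c[n+]([O-])c5ccccc5c3C4=O)nn2)O1` differs from compound 1 as follows: 2,2-dimethyl-1,3-dioxolan-4-yl in place of 5-(hydroxymethyl)-2,2-dimethyl-1,3-dioxolan-4-yl on a saturated chain carbon bound to an aromatic nitrogen. Within the data shown here, no measured step touches the group that changes here, so the data give no direct guide to the size or direction of this change, and it is expected to bring no step beyond the scatter, with no change at the digits printed from compound 1 to compound 4 (within the scatter). Compound 4 is therefore estimated at 370 nM in this assay, with a range from 180 nM to 760 nM.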

Compound 4, half-maximal inhibitory concentration: 4700 nM
Compound 4: middle estimate off by 13-fold (1.10 log units), on the low side; measured number above the stated range.
By their numbers in this assay, from the lowest: compound 2; then compounds 3 and 1 (each within the scatter of the next); then compound 4.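

In this assay, the group on a saturated chain carbon bound to an aromatic nitrogen turns out to matter: replacing 5-(hydroxymethyl)-2,2-dimethyl-1,3-dioxolan-4-yl with 2,2-dimethyl-1,3-dioxolan-4-yl gives a 13-fold higher number from compound 1 to compound 4 (1.10 log units; beyond the scatter), a large step where the amine change on the chain gave only a 2.1-fold higher number from compound 2 to compound 3 (0.32 log units; beyond the scatter). The change removes the hydroxymethyl group, and with it the only hydrogen-bond donor of the group and one defined stereocentre, so a small trim at this position is enough to move the number far upward. No measured evidence is available to explain this step.

These compounds cannot separate the loss of the hydroxymethyl group from the loss of the stereocentre. As far as these compounds go, it also remains open how a methoxymethyl group, an aminomethyl group or the opened diol would behave at this position.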